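From Cyclic Imide to Open Formamide

The source may report more compounds than this note shows. Statements on the series, on what has been measured and on what is new or still open speak of the compounds shown alone.

Measured so far:
compound 1 `COC(=O)CC1CCN(C[C@H]2CN(c3ccc(-n4cc(-c5ccccn5)cn4)c(F)c3)C(=O)O2)CC1`: 1.78
compound 2 `O=C1CNC(=O)N1C[C@H]1CN(c2ccc(-n3cc(-c4ccccn4)cn3)c(F)c2)C(=O)O1`: 1.25

Compound 1 and compound 2 share one core and differ in a single substituent. In a physicochemical assay for lipophilicity, read by HPLC, measured as octanol-water partition (on this read-out lower numbers stand for lower lipophilicity and higher numbers for higher lipophilicity), compound 2 sits lowest of the two numbers, and its nearest neighbour is compound 1, reached by a number 0.53 log units lower from compound 1 to compound 2 (beyond the scatter). That step is the only one in hand, and it exchanges one group for another of different kind, so it does not directly bear on what follows.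

Compound 3 `O=CNC[C@H]1CN(c2ccc(-n3cc(-c4ccccn4)cn3)c(F)c2)C(=O)O1` keeps the core of compound 2 and changes the same position once more: formylamino in place of 2,5-dioxoimidazolidin-1-yl on a saturated chain carbon bound to a saturated ring carbon. The group that leaves carries a ring and two acceptors; the group that enters is smaller, with one donor and one acceptor. Among the compounds with values here, no measured step shows this particular exchange, so the expectation rests on size alone. A modest downward step, a number 0.25 log units lower from compound 2 to compound 3 (within the scatter), is expected. In this assay compound 3 is therefore estimated at 1, within a range of 0.6 to 1.4.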

Compound 3, partition coefficient: 1.19
The estimate for compound 3 lay 0.19 log units below the measured number, within the range that was stated.
By their numbers in this assay, from the lowest: compounds 3 and 2 (each within the scatter of the next); then compound 1.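

In this assay, formylamino in place of 2,5-dioxoimidazolidin-1-yl gives a number 0.06 log units lower from compound 2 to compound 3 (within the scatter), so at this position on a saturated chain carbon bound to a saturated ring carbon, going from a ring group of 7 heavy atoms to an open group of 3 heavy atoms does not separate the two compounds. Against the 4-((methoxycarbonyl)methyl)piperidin-1-yl group, the open group gives a number 0.59 log units lower from compound 1 to compound 3 (beyond the scatter), which places it with the cyclic imide, whose own step is a number 0.53 log units lower from compound 1 to compound 2 (beyond the scatter), so among these three compounds only compound 1 stands apart. No measurement at hand accounts for why the smaller group and the larger ring group read alike here.

The compounds shown leave open whether this likeness holds for other small open groups at the same place, such as a plain amine, an acetylamino group or a longer chain ending in formylamino. They also leave open how much of the separation of compound 1 rests on its methyl ester, which a carboxylic acid on the same piperidine ring would help to show.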